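One Side Chain Exchanged on a Shared Core

The source may report more compounds than this note shows. Statements on the series, on what has been measured and on what is new or still open speak of the compounds shown alone.

Compound 1 `CC1=C(N2CC2)C(=O)C(CC(C)OC(N)=O)=C(N2CC2)C1=O` has been tested in a functional assay on L1210 cells (Mus musculus), with a stated time of 12 days (a lower number here means a less potent compound, a higher number a more potent compound, by a factor of ten per unit of this negative logarithm), where compound 1 gives 6.14. That places it second highest of the three numbers at hand. Compound 3 `CCC(COC(N)=O)C1=C(N2CC2)C(=O)C(C)=C(N2CC2)C1=O` gives 6.18 in this assay, a number within the usual scatter of compound 1, so the two cannot be told apart. Compound 2 `CCCC1=C(N2CC2)C(=O)C(CCC)=C(N2CC2)C1=O` gives 4.92 in this assay, well below compound 1 and beyond the scatter. Compound 4 `COC(CO)C1=C(N2CC2)C(=O)C(C)=C(N2CC2)C1=O` has not been measured yet; it differs from compound 1 as follows: a group of 5 heavy atoms (3 carbon, 2 oxygen; no ring) in place of a group of 7 heavy atoms (4 carbon, 1 nitrogen, 2 oxygen; no ring), on a double-bonded ring carbon. Within the data shown here, no pair of measured compounds shows this exact change. Where compound 1 carries its longer chain, compound 2 carries only a propyl chain, and compound 2 gives 4.92. On that basis a moderate drop, beyond the scatter, is expected for a number 0.64 log units lower from compound 1 to compound 4 (beyond the scatter). Compound 4 is therefore estimated at 5.5, with a range from 4.8 to 6.2.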

Compound 4, logarithm of the reciprocal of the active concentration, log(1/C): 6.9
Estimate against measurement, compound 4: 1.40 log units below; measured number above the stated range.
By their numbers in this assay, from the lowest: compound 2; then compounds 1 and 3 (each within the scatter of the next); then compound 4.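

Placing 2-hydroxy-1-methoxyethyl on this double-bonded ring carbon gives a number 0.76 log units higher from compound 1 to compound 4 (beyond the scatter) in this assay. The nitrogen of the leaving chain is thus not required for a high number at this position, and since both groups carry the same counts of hydrogen-bond donors and acceptors, those counts do not separate them. No measurement at hand accounts for the gain. Which part of the new group matters stays open. An ethoxy group in place of the methoxy, or an amine in place of the hydroxyl, would test each part on its own.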